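Chain variation at the ring-nitrogen neighbour of the shared core

A few compounds are considered here, and "the series" means these few. Any claim that something is new, unique, unknown or untested is made for them only; others in the source may bear on it.

Measured compounds:
compound 1 `CCCCOc1nc(C(C)(C)C)ccc1CNC(=O)C(C)c1ccc(NS(C)(=O)=O)c(F)c1` — 0.9 nM
compound 2 `COCCCOc1nc(C(C)(C)C)ccc1CNC(=O)C(C)c1ccc(NS(C)(=O)=O)c(F)c1` — 5.6 nM

In an assay on cells for antagonist activity at transient receptor potential cation channel subfamily V member 1 (Homo sapiens), read by FLIPR and calcium flux, with a stated time of 6 min (a higher number here means a weaker inhibitor, a lower number a stronger inhibitor), compound 1 gives 0.9 nM, the lowest of the two numbers; compound 2 gives 5.6 nM. Going by the values given here, the only measured step is a 6.2-fold higher number from compound 1 to compound 2 (0.79 log units; beyond the scatter), a methoxy in place of methyl on the chain three bonds from the ring oxygen.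

Compound 3 `CC(C(=O)NCc1ccc(C(C)(C)C)nc1SCCCN(C)C)c1ccc(NS(C)(=O)=O)c(F)c1` differs from compound 1 by (3-(dimethylamino)propyl)sulfanyl in place of butoxy on an aromatic carbon. Among the compounds with values here, this touches the same chain as the step from compound 1 to compound 2, but exchanges the ring oxygen for sulfur as well and brings in a dimethylamino end; it is the larger change, with no measured step of its own kind. Within the data shown here, the one measured step points to a weaker inhibitor, so a step of similar or somewhat greater size in the same direction is expected, an 11-fold higher number from compound 1 to compound 3 (1.05 log units; beyond the scatter). Compound 3 is therefore estimated at 10 nM, within 2 nM to 60 nM.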

Compound 3, inhibition constant: 51.8 nM
Beside the measured number, compound 3's estimate is 5.2-fold (0.71 log units) below it, and the stated range covers the measured number.
By their numbers in this assay, from the lowest: compound 1; then compound 2; then compound 3.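

In this assay, the ring-oxygen chains do not mark the limit of change at this position: replacing butoxy with (3-(dimethylamino)propyl)sulfanyl gives a 58-fold higher number from compound 1 to compound 3 (1.76 log units; beyond the scatter), the largest step in this set. The same chain also loses ground against the methoxy-ended ether, with a 9.3-fold higher number from compound 2 to compound 3 (0.97 log units; beyond the scatter), so compound 3 has the highest number of the three and both ethers stay ahead of it. No measurement here accounts for these steps.

Compound 3 changes the linking atom and the chain end together, so the share of each in the rise remains unresolved. A 3-(dimethylamino)propoxy chain and a butylsulfanyl chain on the shared core would separate the sulfur exchange from the dimethylamino end.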